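Swapping the Halogen Pattern on a Benzyl Ring

The source may hold more compounds than are shown below. What is called first, only, known or untested is meant among the compounds shown, and "the series" means these compounds.

Compound 1, `C[C@H](NC(=O)C(=O)NCC1CCCCC1)C(=O)N[C@@H](CC(=O)O)C(=O)COc1c(F)c(F)cc(F)c1F`: 19 nM
Compound 2, `Cc1cccc(CNC(=O)C(=O)N[C@@H](C)C(=O)N[C@@H](CC(=O)O)C(=O)COc2c(F)c(F)cc(F)c2F)c1`: 127 nM
Compound 3, `C[C@H](NC(=O)C(=O)NCc1cccc(F)c1)C(=O)N[C@@H](CC(=O)O)C(=O)COc1c(F)c(F)cc(F)c1F`: 106 nM

The three measured compounds share one core and differ only in the group on a saturated chain carbon bound to an amide-type nitrogen. In a functional assay on Jurkat cells (Homo sapiens) (a higher number here means a weaker inhibitor, a lower number a stronger inhibitor), compound 3 has the second-highest number of the three. Its nearest neighbour is compound 2, and the step of a 1.2-fold lower number from compound 2 to compound 3 (0.08 log units; within the scatter) lies within the scatter, so the two cannot be told apart. The step of a 5.6-fold higher number from compound 1 to compound 3 (0.75 log units; beyond the scatter) lies beyond the scatter, as does a 6.7-fold higher number from compound 1 to compound 2 (0.83 log units; beyond the scatter), so both aromatic groups give a higher number than the cyclohexyl of compound 1.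

Compound 4, `C[C@H](NC(=O)C(=O)NCc1c(Cl)cccc1Cl)C(=O)N[C@@H](CC(=O)O)C(=O)COc1c(F)c(F)cc(F)c1F`, differs from compound 3 in one place: 2,6-dichlorophenyl in place of 3-fluorophenyl on a saturated chain carbon bound to an amide-type nitrogen. Going by the values given here, no measured step exchanges one halogen pattern on the aromatic ring for another, so the only guide is a 1.2-fold lower number from compound 2 to compound 3 (0.08 log units; within the scatter), which shows that changing a single ring substituent stayed within the scatter. On that basis compound 4 is expected to move from compound 3 by a 1.1-fold lower number from compound 3 to compound 4 (0.03 log units; within the scatter), with no change beyond the scatter. The estimate for compound 4 in this assay is 100 nM, within a range of 30 nM to 400 nM.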

Compound 4, half-maximal inhibitory concentration: 110 nM
Compound 4: middle estimate off by 1.1-fold (0.04 log units), on the low side; measured number inside the range.
By their numbers in this assay, from the lowest: compound 1; then compounds 3, 4 and 2 (each within the scatter of the next).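

In this assay, the step of a 1.0-fold higher number from compound 3 to compound 4 (0.02 log units; within the scatter) and the step of a 1.2-fold lower number from compound 2 to compound 4 (0.06 log units; within the scatter) show that 2,6-dichlorophenyl cannot be told apart from 3-fluorophenyl or 3-methylphenyl, so three differently substituted aromatic rings now give matching numbers at this position. The step of a 5.8-fold higher number from compound 1 to compound 4 (0.76 log units; beyond the scatter) keeps cyclohexyl apart from this new ring as well, so among these four compounds the only readable difference lies between cyclohexyl and the substituted phenyl groups, not among those phenyl groups. No measurement available here explains either the match among the aromatic rings or the gap to cyclohexyl.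

The compounds shown leave open whether a plain phenyl, or a phenyl carrying an amine or a carboxylic acid, would match these aromatic groups. They also leave open whether a cyclopentyl group, or a longer chain ending in cyclohexyl, would give a number close to that of compound 1.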